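The source may hold more compounds than are shown below. What is called first, only, known or untested is meant among the compounds shown, and "the series" means these compounds.

Compound 1 `COc1cc(-c2nnc3n2NC(c2ccco2)C(C(=O)c2ccco2)S3)cc(OC)c1OC`: in a functional assay on MCF7 cells (Homo sapiens) for cytotoxicity, read by MTT assay, with a stated time of 48 h (a lower number here means a stronger inhibitor, a higher number a weaker inhibitor), compound 1 gives only a limit, > 100000 nM.
Compound 2 `COc1cc(-c2nnc3n2NC(c2ccco2)C(C(=O)c2ccc(Cl)cc2)S3)cc(OC)c1OC`: compound 2 likewise gives only a limit, > 100000 nM.
Compound 3 `COc1cc(-c2nnc3n2NC(c2ccco2)C(C(=O)c2ccccc2)S3)cc(OC)c1OC`: compound 3 gives 39800 nM.

Compound 1 therefore stands at the limit of this assay, where two of the three values sit (the limit of > 100000 nM in this assay, at which 2 of the 3 values shown sit). Compound 4 `COc1cc(-c2nnc3n2NC(c2ccco2)C(C(=O)c2ccc(O)cc2)S3)cc(OC)c1OC` differs from it by 4-hydroxyphenyl in place of furan-2-yl on a carbonyl carbon. The step bearing most on this change is an at least 2.5-fold lower number from compound 1 to compound 3 (0.40 log units; beyond the scatter), also an exchange of furan-2-yl for a six-membered carbon ring; the step that the two limits leave unreadable from compound 1 to compound 2 cannot be read, while an at least 2.5-fold lower number from compound 2 to compound 3 (0.40 log units; beyond the scatter) shows that a substituent on that ring can shift the number. For the measured compounds named here, for 4-hydroxyphenyl itself no measured pair exists. The expected step is a lower number, an at least 2.0-fold lower number from compound 1 to compound 4 (0.30 log units; that floor lies within the scatter), of at least modest size. Compound 4 is thus estimated at 50000 nM, within 15000 nM to 150000 nM.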

Compound 4, half-maximal inhibitory concentration: 88900 nM
The estimate for compound 4 lay 1.8-fold (0.25 log units) below the measured number; the measured number falls inside the stated range.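

In this assay, for the compounds shown here, hydroxy in place of hydrogen on an aromatic carbon gives a 2.2-fold higher number from compound 3 to compound 4 (0.35 log units; beyond the scatter), the first step at this carbonyl with a substituted ring that has a number at both ends. Against the two limits, the change gives an at least 1.1-fold lower number from compound 1 to compound 4 (0.05 log units; that floor lies within the scatter) and an at least 1.1-fold lower number from compound 2 to compound 4 (0.05 log units; that floor lies within the scatter), floors that lie within the scatter, so neither step settles how compound 4 compares: the limit of > 100000 nM in this assay, at which 2 of the 4 values shown sit.

On these data alone, whether a methoxy or an amino group on the phenyl ring would shift the number in the same direction stays open. As far as these compounds go, the true sizes of the steps from furan-2-yl and 4-chlorophenyl also stay open.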